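A few compounds are considered here, and "the series" means these few. Any claim that something is new, unique, unknown or untested is made for them only; others in the source may bear on it.

Compound 1 `CC(C(=O)N1CCC(F)(F)CC1)N1CCN(S(=O)(=O)c2ccc(C(C)(C)C)cc2)CC1`: > 40000 nM
Compound 2 `CC1CCN(C(=O)C(C)N2CCN(S(=O)(=O)c3ccc(C(C)(C)C)cc3)CC2)CC1`: > 40000 nM

In an ADME assay on HepG2 cells (Homo sapiens) for inhibition, with a stated time of 48 h (on this read-out lower numbers stand for an effect already at smaller amounts and higher numbers for an effect only at larger amounts of compound), compound 1 reaches only a limit of the assay, > 40000 nM. Compound 2 likewise shows only a limit, > 40000 nM. The step that the two limits leave unreadable from compound 1 to compound 2 therefore cannot be read in size or direction. Compound 2 thus stands at the limit of > 40000 nM in this assay, at which 2 of the 2 values shown sit. Compound 3 `CC(C(=O)N1CCCc2ccccc21)N1CCN(S(=O)(=O)c2ccc(C(C)(C)C)cc2)CC1` differs from compound 2 by 1,2,3,4-tetrahydroquinolin-1-yl in place of 4-methylpiperidin-1-yl on a carbonyl carbon. Among the compounds with values here, no measured step informs this change, since the only step available, a step that the two limits leave unreadable from compound 1 to compound 2, is unreadable. Compound 3 is accordingly expected to remain at the limit, the step that the limit leaves unreadable from compound 2 to compound 3 being an estimate without a readable direction. The estimate for compound 3 is 60000 nM, between 20000 nM and 200000 nM.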

Compound 3, half-maximal effective concentration: > 40000 nM
Compound 3: no number, only a limit (the forecaster's own chance of this, stated with the estimate: 85%); the middle value is on the limit's open side.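

Within the data shown here, compound 1, compound 2 and compound 3 all stand only at a limit in this assay, so no step among them can be read. The compounds shown leave open how the groups on the carbonyl carbon compare in size of effect.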